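The compounds below may be only part of what the source reports. "The series", "measured", "known", "first", "only" and "open" are said of these compounds alone.

Measured so far, in an ADME assay on isolated protein for inhibition of peroxidase (Raphanus sativus), read by fluorescence and Amplex Red; a higher number here means a weaker inhibitor, a lower number a stronger inhibitor:
- compound 1, `Oc1ccccc1NC(=S)Nc1ccc2[nH]ccc2c1`: 800 nM
- compound 2, `Oc1ccc(NC(=S)Nc2ccc3[nH]ccc3c2)cc1`: 1010 nM

Compound 2 stands at the upper end of these two numbers, yet its gap to compound 1 lies within the usual scatter, so the two cannot be told apart in this assay. Compound 3, `Oc1ccc(NC(=S)Nc2ccc3[nH]ccc3c2)cc1Cl`, is not yet measured. It differs from compound 2 by one change: chloro in place of hydrogen on an aromatic carbon. Within the data shown here, no measured pair shows this change, so the size of the step is open; the expectation is a step no larger than the scatter, in either direction. Compound 3 is estimated at 900 nM, within 400 nM to 2000 nM, a step of a 1.1-fold lower number from compound 2 to compound 3 (0.05 log units; within the scatter) expected from the value of compound 2.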

Compound 3, half-maximal inhibitory concentration: 1010 nM
The estimate for compound 3 lay 1.1-fold (0.05 log units) below the measured number; low and high end bracket the measured number.
By their numbers in this assay, from the lowest: compounds 1, 2 and 3 (each within the scatter of the next).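

In this assay, chloro in place of hydrogen on this aromatic carbon, ortho to a hydroxy group, gives no change at the digits printed from compound 2 to compound 3 (within the scatter). Among these compounds, this is the first step measured at this position, and it shows that one chlorine atom can stand here without a readable shift in the number. Nothing available speaks to the reason for this result.

On these data alone, whether a methoxy group, an amine or a longer chain at the same carbon would shift the number remains open. So does the effect of a carboxylic acid in place of the hydroxy group.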